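Swapping diethylamino for 4-methylpiperazin-1-yl on the shared core

The source may report more compounds than this note shows. Statements on the series, on what has been measured and on what is new or still open speak of the compounds shown alone.

Three compounds have numbers in an ADME assay on HEK-293T cells (Homo sapiens) for cytotoxicity, read by CCK-8 assay, with a stated time of 48 h; a lower number here means that less compound is tolerated, a higher number that more compound is tolerated. Compound 1 (`O=C(CNc1nc(N2CCc3ccccc3C2)nc2ccccc12)Nc1ccc2ccccc2c1`) gives > 100000 nM, which is a limit. Compound 2 (`O=C(CNc1nc(N2CCc3ccccc3C2)nc2ccccc12)NCc1ccccc1`) gives 29400 nM. Compound 3 (`CCN(CC)c1nc(NCC(=O)NCc2ccccc2)c2ccccc2n1`) gives > 100000 nM, also a limit. That places it at the limit of > 100000 nM in this assay, at which 2 of the 3 values shown sit.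

Compound 4 (`CN1CCN(c2nc(NCC(=O)NCc3ccccc3)c3ccccc3n2)CC1`) carries 4-methylpiperazin-1-yl in place of diethylamino on an aromatic carbon. The change at the amide-type nitrogen, an at least 3.4-fold lower number from compound 1 to compound 2 (0.53 log units; beyond the scatter), lies elsewhere and bears only loosely. The closest guide is the change at this same place, an at least 3.4-fold higher number from compound 2 to compound 3 (0.53 log units; beyond the scatter), where a ring gave way to diethylamino. A ring now returns, so a modest fall in this assay is expected, and the expected step is an at least 1.6-fold lower number from compound 3 to compound 4 (0.22 log units; that floor lies within the scatter). Compound 4 is estimated at 60000 nM, within a range of 20000 nM to 100000 nM.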

Compound 4, half-maximal cytotoxic concentration: > 100000 nM
Compound 4: a limit, no number (the forecaster's own chance of this, stated with the estimate: 45%); middle value at least 1.6-fold (0.22 log units) away from the limit.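

Putting 4-methylpiperazin-1-yl in place of 1,2,3,4-tetrahydroisoquinolin-2-yl gives an at least 3.4-fold higher number from compound 2 to compound 4 (0.53 log units; beyond the scatter) in this assay. A ring at this position is therefore not enough by itself to bring the number down, so the fall seen with compound 2 belongs to that one ring group, not to rings here in general. The step from compound 3 to compound 4 cannot be read, because both values are limits: the limit of > 100000 nM in this assay, at which 3 of the 4 values shown sit.

From the compounds shown here alone, how far compound 3 and compound 4 lie past that limit stays open. Also open, going by these compounds, is whether piperidin-1-yl or morpholin-4-yl at this position would give a measurable number.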